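Urea-to-benzamide step in a pyrazole series

A few compounds are considered here, and "the series" means these few. Any claim that something is new, unique, unknown or untested is made for them only; others in the source may bear on it.

Measured so far:
compound 1, `COc1cc(-c2nn(-c3cccc(NC(=O)Nc4cc(C(F)(F)F)cc(C(F)(F)F)c4)c3)cc2-c2ccncc2)ccc1Cl`, 4720 nM
compound 2, `COc1cc(-c2nn(-c3cccc(NC(=O)Nc4cccc(C(F)(F)F)c4)c3)cc2-c2ccncc2)ccc1Cl`, > 50000 nM

In a functional assay on HOP-92 cells (Homo sapiens) for inhibition, read by sulforhodamine B assay, with a stated time of 48 h (on this read-out lower numbers stand for higher toxicity in this test and higher numbers for lower toxicity in this test), compound 1 gives 4720 nM. Compound 2 shows only a limit of the assay, > 50000 nM, so its place among the numbers is open-ended; it sits at the limit of > 50000 nM in this assay, at which 1 of the 2 values shown sits. Within the data shown here, the one measured step, an at least 10-fold higher number from compound 1 to compound 2 (1.02 log units; beyond the scatter), is large, and removing one trifluoromethyl already carried the number to the limit.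

Compound 3, `COc1cc(-c2nn(-c3cccc(NC(=O)c4ccccc4)c3)cc2-c2ccncc2)ccc1Cl`, is not yet measured. It differs from compound 2 by phenyl in place of (3-(trifluoromethyl)phenyl)amino on a carbonyl carbon, so the remaining trifluoromethyl and the amino of the urea both go. Among the measured compounds shown here, the only step that bears on this, the one from compound 1 to compound 2, points to a higher number when a trifluoromethyl is lost, but since compound 2 is already at the limit, no further step in this assay can be resolved; the expectation is that compound 3 also reports a limit, giving an estimated step that the limit leaves unreadable from compound 2 to compound 3. Compound 3 is therefore expected at about 70000 nM, within 20000 nM to 200000 nM.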

Compound 3, concentration lethal to 50% of the cells: > 100000 nM
Compound 3: no number, only a limit (the forecaster's own chance of this, stated with the estimate: 75%); middle value at least 1.4-fold (0.15 log units) from the limit.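

Among these compounds, compound 2 and compound 3 both give only limits of the assay in this assay, so no step between them can be read. Still open, as far as these compounds go, is whether phenyl in place of (3-(trifluoromethyl)phenyl)amino on a carbonyl carbon changes the number in this assay at all.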